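A few compounds are considered here, and "the series" means these few. Any claim that something is new, unique, unknown or untested is made for them only; others in the source may bear on it.

In an assay on isolated protein for inhibition of DNA topoisomerase 1 (Homo sapiens), with a stated time of 15 min (a higher number here means a weaker inhibitor, a lower number a stronger inhibitor), compound 1, `CNC[C@@H]1CCN(c2c(F)cc3c(=O)c(C(=O)O)cn(Cc4ccc(-c5ccccc5)cc4)c3c2OC)C1`, gives 155000 nM. Compound 2, `COc1c(N2CC[C@@H](C(N)=O)C2)c(F)cc2c(=O)c(C(=O)O)cn(Cc3ccc(-c4ccccc4)cc3)c12`, reaches only the limit of this assay, > 200000 nM. Compound 3, `COc1c(N2CC[C@@H](CO)C2)c(F)cc2c(=O)c(C(=O)O)cn(Cc3ccc(-c4ccccc4)cc3)c12`, likewise stands at the limit, > 200000 nM, so for compound 3 only a bound is known and no number. The steps recorded are an at least 1.2-fold higher number from compound 1 to compound 2 (0.11 log units; that floor lies within the scatter) and an at least 1.2-fold higher number from compound 1 to compound 3 (0.11 log units; that floor lies within the scatter), while a step that the two limits leave unreadable from compound 2 to compound 3; all of this rests on (the limit of > 200000 nM in this assay, at which 2 of the 3 values shown sit).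

Compound 4, `CNCCNc1c(F)cc2c(=O)c(C(=O)O)cn(Cc3ccc(-c4ccccc4)cc3)c2c1OC`, differs from compound 3 by (2-(methylamino)ethyl)amino in place of 3-(hydroxymethyl)pyrrolidin-1-yl on an aromatic carbon. For the measured compounds named here, the measured steps bear on it only loosely: the one compound carrying a methylamino group, compound 1, is the only one to give a number at all, whereas the hydroxymethyl and carbamoyl analogues sit at the limit. A methylamino group returns in compound 4, on an open chain in place of a ring. Compound 4 is therefore expected to come back within the readable range, near 150000 nM, between 50000 nM and 400000 nM, which means an expected step of an at least 1.3-fold lower number from compound 3 to compound 4 (0.12 log units; that floor lies within the scatter), though a further limit cannot be excluded.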

Compound 4, half-maximal inhibitory concentration: > 200000 nM
Compound 4: a limit, no number; the forecaster's own chance of this, stated with the estimate: 45%; middle value at least 1.3-fold (0.12 log units) from the limit.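

In this assay compound 4 gives > 200000 nM, which is a limit and not a number. A methylamino group on the open (2-(methylamino)ethyl)amino chain therefore gives no readable value here, so among these compounds a methylamino group alone does not secure one. The only readable step is an at least 1.2-fold higher number from compound 1 to compound 4 (0.11 log units; that floor lies within the scatter), and the steps to compound 4 from compound 2 and compound 3 cannot be read: the limit of > 200000 nM in this assay, at which 3 of the 4 values shown sit.

From the compounds shown here alone, how far compound 2, compound 3 and compound 4 lie past the limit remains open, and so does whether the five-membered ring of compound 1 contributes to its readable value. Also open, going by these compounds, is what a primary amine, a dimethylamino group or a longer chain would give on this aromatic carbon.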